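A few compounds are considered here, and "the series" means these few. Any claim that something is new, unique, unknown or untested is made for them only; others in the source may bear on it.

Measured compounds in an assay on frontal cortex for displacement of a labelled ligand from corticotropin-releasing factor receptor 1 (Rattus norvegicus); on this read-out higher numbers stand for weaker inhibition and lower numbers for stronger inhibition:
- compound 1 `CCCCN(CC)c1nc(C)nc2c1NCCN2c1ccc(OC)cc1C`: 11.7 nM
- compound 2 `CCCCN(CC)c1cc(C)nc2c1NCCN2c1ccc(OC)nc1OC`: 2.2 nM
- compound 3 `CCCCN(CC)c1nc(C)nc2c1NCCN2c1ccc(C#N)cc1C`: 102 nM

Compound 3 gives the highest number of the three in this assay; compound 1 is the nearest, compound 2 the furthest, and both gaps lie beyond the scatter. Going by the values given here, the only single-point step measured so far is an 8.7-fold higher number from compound 1 to compound 3 (0.94 log units; beyond the scatter), which shows a modest weakening when the methoxy gives way to cyano. Compound 2 differs from the others in more than one place, so nothing is drawn from it for this step.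

Compound 4 `CCCCN(CC)c1nc(C)nc2c1NCCN2c1ccc(C(C)=O)cc1C` carries acetyl in place of cyano on an aromatic carbon. Among the compounds with values here, no measured pair exchanges cyano for acetyl, so the step rests on the single step into compound 3 alone, which marks that position as one where the substituent matters. Within the data shown here, with no direct precedent, the expected change is small and uncertain in sign: the estimate for compound 4 is 80 nM, with a range of 25 nM to 260 nM, meaning an expected step of a 1.3-fold lower number from compound 3 to compound 4 (0.11 log units; within the scatter) in this assay.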

Compound 4, half-maximal inhibitory concentration: 172 nM
Compound 4: the middle estimate sits 2.2-fold (0.33 log units) below what was measured; measured number inside the range.
By their numbers in this assay, from the lowest: compound 2; then compound 1; then compounds 3 and 4 (each within the scatter of the next).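

In this assay, acetyl in place of cyano on this aromatic carbon gives a step that stays within the scatter (a 1.7-fold higher number from compound 3 to compound 4 (0.23 log units; within the scatter)), so the two groups cannot be separated here. Acetyl in place of methoxy gives a large step (a 15-fold higher number from compound 1 to compound 4 (1.17 log units; beyond the scatter)), which joins the earlier modest one (an 8.7-fold higher number from compound 1 to compound 3 (0.94 log units; beyond the scatter)) and means that two different replacements for methoxy, rather than one, now move the number upward at this position. No measured data accompany these compounds that would explain this pattern.

As far as these compounds go, it remains open whether any group other than methoxy here can keep the low number of compound 1, and ethoxy, chlorine or a dimethylamino group would test that. Whether acetyl and cyano behave alike on the core of compound 2 is also unresolved.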